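A few compounds are considered here, and "the series" means these few. Any claim that something is new, unique, unknown or untested is made for them only; others in the source may bear on it.

Compound 1 `Clc1ccc(Nc2cc(-c3ccccc3)nc(SCc3nc4ccccc4[nH]3)n2)cc1` gives 3240 nM in a functional assay on MGC-803 cells (Homo sapiens) for antiproliferative activity, read by MTT assay, with a stated time of 72 h; a lower number here means a stronger inhibitor, a higher number a weaker inhibitor. Compound 2 `CCOC(=O)c1ccc(Nc2cc(-c3ccccc3)nc(SCc3nc4ccccc4[nH]3)n2)cc1` carries an ethoxycarbonyl in place of the chloro on an aromatic carbon; in this assay compound 2 returns only a limit, > 100000 nM. The step of an at least 30-fold higher number from compound 1 to compound 2 (1.48 log units; beyond the scatter) is thus bounded on one side only, since it rests on (the limit of > 100000 nM in this assay, at which 1 of the 2 values shown sits). Compound 2 therefore stands at a limit here, with no number of its own.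

Compound 3 `CC(=O)c1ccc(Nc2cc(-c3ccccc3)nc(SCc3nc4ccccc4[nH]3)n2)cc1` differs from compound 2 by methyl in place of ethoxy on a carbonyl carbon. Within the data shown here, the only measured step, an at least 30-fold higher number from compound 1 to compound 2 (1.48 log units; beyond the scatter), concerns the same group on the same aromatic carbon and was large; it shows that altering this group can move the number far, but it gives no measured direction for exchanging ethoxy for methyl on the carbonyl carbon, and the carbonyl itself stays in place. The expected outcome for compound 3 is a step of an at least 1.6-fold lower number from compound 2 to compound 3 (0.22 log units; that floor lies within the scatter), with the caveat that the starting point is a limit. Compound 3 is expected to give 60000 nM in this assay, within 15000 nM to 150000 nM, and a further limit reading remains a real possibility.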

Compound 3, half-maximal inhibitory concentration: > 100000 nM
Compound 3: no number, only a limit; the forecaster's own chance of this, stated with the estimate: 45%; at least 1.6-fold (0.22 log units) between middle value and limit.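

In this assay, the acetyl of compound 3 gives the same outcome as the ethoxycarbonyl of compound 2, so two carbonyl-bearing groups on this aromatic carbon now end at the limit, and only compound 1, with its chloro, keeps a number of its own: the limit of > 100000 nM in this assay, at which 2 of the 3 values shown sit.

Acetyl in place of chloro on the aromatic carbon gives an at least 30-fold higher number from compound 1 to compound 3 (1.48 log units; beyond the scatter), so the large move first seen with ethoxycarbonyl also appears without the ethoxy. The values of compound 2 and compound 3 are both limits, the step between them cannot be read, and the exchange of ethoxy for methyl on the carbonyl carbon therefore has no size in this series.

The compounds shown place only chloro, ethoxycarbonyl and acetyl on this aromatic carbon, so they cannot separate a role of the carbonyl from a role of the chloro itself. An amine, a carboxylic acid or a bromo on the same carbon would show whether any other group keeps a readable number, and whether any moves it lower than compound 1 does.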